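A few compounds are considered here, and "the series" means these few. Any claim that something is new, unique, unknown or untested is made for them only; others in the source may bear on it.

Working notes on the series. The reference point is compound 1 `COc1ccc(Br)cc1C(=O)Nc1ccc(Sc2nc3ccccc3s2)cc1`. In an assay for inhibition of HSP60/HSP10 (Homo sapiens), with a stated time of 60 min (on this read-out higher numbers stand for weaker inhibition and lower numbers for stronger inhibition), compound 1 gives only a limit, > 100000 nM. Compound 1 therefore stands at the upper edge of the numbers seen here, with no measured figure of its own; two of the three values shown sit at the limit of > 100000 nM in this assay, at which 2 of the 3 values shown sit. Compound 2 `O=C(Nc1cccc(Cl)c1)c1cc(Br)cc(Br)c1O` gives 29000 nM in this assay. Compound 3 `O=C(Nc1cccc(Cl)c1)c1ccccc1O` again returns only a limit, > 100000 nM. Within the data shown here, no two measured compounds differ in a single place, so no measured step is available. Compound 4 `COc1c(Br)cccc1C(=O)Nc1ccc(Sc2nc3ccccc3s2)cc1` differs from compound 1 by a group of 9 heavy atoms (7 carbon, 1 oxygen, 1 bromine; one six-membered aromatic ring of carbon only) in place of a group of 9 heavy atoms (7 carbon, 1 oxygen, 1 bromine; one six-membered aromatic ring of carbon only), on a carbonyl carbon. Since bromine and methoxy stay on the same ring and only their arrangement changes, the step of a number no higher from compound 1 to compound 4 (the limit leaves the size open) is expected to be essentially none. Compound 4 is thus estimated at 100000 nM, between 30000 nM and 300000 nM.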

Compound 4, half-maximal inhibitory concentration: > 100000 nM
Compound 4: only a limit was reported; the forecaster's own chance of this, stated with the estimate: 70%; the middle value lies on the limit itself.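

Compound 1 and compound 4 both return only a limit in this assay, so no step can be read between them: the limit of > 100000 nM in this assay, at which 3 of the 4 values shown sit.

The compounds shown leave open whether rearranging bromine and methoxy on that ring changes inhibition at all.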